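Swapping a Chlorine Group for Three Methoxy Groups

The compounds below may be only part of what the source reports. "The series", "measured", "known", "first", "only" and "open" are said of these compounds alone.

Compound 1, `COC(=O)c1cc(-c2cccc(NC(=O)c3ccc(/C=C/C(=O)c4cccnc4)cc3)c2)on1`, in an ADME assay on Vero cells (Chlorocebus sabaeus) for cytotoxicity, read by MTT assay, with a stated time of 72 h; on this read-out higher numbers stand for lower toxicity in this test and lower numbers for higher toxicity in this test: "not determined" (no result reported).
Compound 2, `COC(=O)c1cc(-c2cccc(NC(=O)c3ccc(/C=C/C(=O)c4ccc(F)cc4F)cc3)c2)on1`: > 40 ug/mL, a limit of the test.
Compound 3, `COC(=O)c1cc(-c2cccc(NC(=O)c3ccc(/C=C/C(=O)c4ccc(Cl)cc4)cc3)c2)on1`: > 50 ug/mL, also a limit of the test.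

Compound 3 stands at a limit of this assay, as the limit of > 50 ug/mL in this assay, at which 1 of the 3 values shown sits, shows. Compound 2 likewise stands at a limit, (the limit of > 40 ug/mL in this assay, at which 1 of the 3 values shown sits). Compound 1 has no result. The step that the two limits leave unreadable from compound 2 to compound 3 therefore cannot be read. Compound 4, `COC(=O)c1cc(-c2cccc(NC(=O)c3ccc(/C=C/C(=O)c4cc(OC)c(OC)c(OC)c4)cc3)c2)on1`, differs from compound 3 by 3,4,5-trimethoxyphenyl in place of 4-chlorophenyl on a carbonyl carbon. Among the compounds with values here, no measured step bears directly on this change, and the only step available is unreadable. Compound 4 is expected to give 60 ug/mL, within 30 ug/mL to 120 ug/mL, most likely again a limit. The expected step that the limit leaves unreadable from compound 3 to compound 4 means no change beyond the scatter.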

Compound 4, half-maximal cytotoxic concentration: > 50 ug/mL
Compound 4: no number, only a limit; the forecaster's own chance of this, stated with the estimate: 70%; the middle value lies beyond the limit too.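

Within the data shown here, compound 2, compound 3 and compound 4 all give only limits in this assay, and no step among them can be read. From the compounds shown here alone, whether the different groups on the carbonyl carbon change toxicity in this assay at all remains open.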